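A few compounds are considered here, and "the series" means these few. Any claim that something is new, unique, unknown or untested is made for them only; others in the source may bear on it.

Measured so far in an ADME assay on microsomes from liver (Homo sapiens) for metabolic stability, with a stated time of 5 min; a higher number here means that more of the compound is left, a lower number that less of the compound is left:
- compound 1 `CN1CCc2nc(C(=O)N[C@@H]3CC[C@@H](C(=O)O)C[C@@H]3NC(=O)c3cc4cc(Cl)ccc4[nH]3)sc2C1` gives 97%
- compound 2 `CN1CCc2nc(C(=O)N[C@@H]3CC[C@@H](C(=O)N(C)C)C[C@@H]3NC(=O)c3cc4cc(Cl)ccc4[nH]3)sc2C1` gives 36%

Compound 1 holds the higher of the two numbers. Among the compounds with values here, the only measured step, large and beyond the scatter, is a number 61 percentage points lower from compound 1 to compound 2 (beyond the scatter), with dimethylamino in place of hydroxy on a carbonyl carbon.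

Next comes compound 3 `CN1CCc2nc(C(=O)N[C@@H]3CC[C@H](C(=O)O)C[C@@H]3NC(=O)c3cc4cc(Cl)ccc4[nH]3)sc2C1`, where (the two compounds have the same atoms and bonds and differ only in configuration as drawn: 1 of 3 stereo elements differ; a stereocentre at a saturated ring carbon is drawn R in compound 1 and S in compound 3), so a stereocentre at a saturated ring carbon is drawn S rather than R. No measured step covers a change of configuration, so the large step above bears on it only indirectly. Compound 3 keeps the hydroxy of compound 1 at 97%, and the expectation in this assay is therefore a small drop, probably within the scatter. The expected step is a number 7 percentage points lower from compound 1 to compound 3 (within the scatter) and remains uncertain. For compound 3 the estimate is 90%, with an expected range from 72% to 100%.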

Compound 3, percent of the compound remaining: 98%
Compound 3: middle estimate off by 8 percentage points, on the low side, within the range that was stated.
By their numbers in this assay, from the lowest: compound 2; then compounds 1 and 3 (each within the scatter of the next).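

In this assay, within the data shown here, the step is a number 1 percentage points higher from compound 1 to compound 3 (within the scatter), the first reading on a change of configuration. The pair is a clean test of the stereocentre at the saturated ring carbon, drawn R in compound 1 and S in compound 3: the fact that compounds 1 and 3 differ only in the configuration as drawn. With hydroxy on the carbonyl carbon, this stereocentre therefore makes no difference beyond the scatter, whereas the change of group gave a number 61 percentage points lower from compound 1 to compound 2 (beyond the scatter).

The compounds shown leave open whether the S configuration would give a similar reading with dimethylamino on the carbonyl carbon, since the change of configuration is seen here only with hydroxy in that place. They also leave open how methylamino or a plain amino group on the same carbonyl carbon would read in this assay.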